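A few compounds are considered here, and "the series" means these few. Any claim that something is new, unique, unknown or untested is made for them only; others in the source may bear on it.

Measured in a functional assay on NCI-H23 cells (Homo sapiens) for antiproliferative activity, read by MTT assay, with a stated time of 72 h; on this read-out lower numbers stand for stronger inhibition and higher numbers for weaker inhibition:
- compound 1 `C=CC(=O)Nc1cc(Nc2nccc(NC(=O)c3cccc4ccccc34)n2)c(OC)cc1N1CCN(C)CC1`: 10600 nM
- compound 2 `C=CC(=O)Nc1cc(Nc2nccc(NC(=O)c3cccc(OC)c3)n2)c(OC)cc1N1CCN(C)CC1`: 15900 nM
- compound 3 `C=CC(=O)Nc1cc(Nc2nccc(NC(=O)c3ccccc3)n2)c(OC)cc1N(C)CCN(C)C`: > 16000 nM (a limit)

Compound 3 has no number, only (the limit of > 16000 nM in this assay, at which 1 of the 3 values shown sits). In compound 4 `C=CC(=O)Nc1cc(Nc2nccc(NC(=O)c3ccccc3)n2)c(OC)cc1N1CCN(C)CC1`, 4-methylpiperazin-1-yl takes the place of (2-(dimethylamino)ethyl)(methyl)amino on an aromatic carbon (4-methylpiperazin-1-yl in place of (2-(dimethylamino)ethyl)(methyl)amino on an aromatic carbon). For the measured compounds named here, no measured step covers this change directly. Going by the values given here, the one measured step, a 1.5-fold higher number from compound 1 to compound 2 (0.18 log units; within the scatter), is a change on a carbonyl carbon and stays within the scatter. Compound 1 carries the entering group and gives 10600 nM, and compound 2 carries it and gives 15900 nM, so compound 4 is expected near these values in this assay. The expected step is an at least 1.2-fold lower number from compound 3 to compound 4 (0.09 log units; that floor lies within the scatter), with no shift beyond the scatter anticipated. For compound 4 the estimate is 13000 nM, with an expected range of 7000 nM to 24000 nM.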

Compound 4, half-maximal inhibitory concentration: > 16000 nM
Compound 4 gave a limit, no number; the forecaster's own chance of this, stated with the estimate: 35%; at least 1.2-fold (0.09 log units) between middle value and limit.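

In this assay, 4-methylpiperazin-1-yl in place of (2-(dimethylamino)ethyl)(methyl)amino, on the aromatic carbon ortho to the (vinylcarbonyl)amino group, leaves the phenyl amide at a limit, so the step to compound 4 from compound 3 cannot be read. With 4-methylpiperazin-1-yl held, hydrogen in place of methoxy gives a number no lower from compound 2 to compound 4 (the limit leaves the size open), and phenyl in place of naphthalen-1-yl gives an at least 1.5-fold higher number from compound 1 to compound 4 (0.17 log units; that floor lies within the scatter), which fixes no order among these amides. Comparison at this position stays closed: the limit of > 16000 nM in this assay, at which 2 of the 4 values shown sit.

Open, on these data alone, is whether the two amine groups differ when the amide carries naphthalen-1-yl. Also open, as far as these compounds go, is how a morpholine or a plain dimethylamino group would read at this place.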